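Swapping propyl for propargyl beside a sulfur

The source may report more compounds than this note shows. Statements on the series, on what has been measured and on what is new or still open speak of the compounds shown alone.

Among the measured compounds shown here, compound 3 `CCCSc1nc(N/N=C/c2c(O)ccc3ccccc23)c2nnn(Cc3ccccc3)c2n1` is one of three compounds so far tested in a functional assay on MCF7 cells (Homo sapiens) for antiproliferative activity, read by MTT assay, with a stated time of 72 h; a lower number here means a stronger inhibitor, a higher number a weaker inhibitor. Compound 1 `CCCSc1nc(N/N=C/c2ccc(C)cc2)c2nnn(Cc3ccccc3)c2n1` returns only a limit of the assay in this assay, namely > 64000 nM. Compound 2 `C#CCSc1nc(N/N=C/c2ccc(N(C)C)cc2)c2nnn(Cc3ccccc3)c2n1` likewise returns only a limit in this assay, > 64000 nM. Compound 3 is thus the only one of the three with an actual number: in this assay compound 3 gives 6400 nM. For the measured compounds named here, the single measured step between compounds differing in one place runs from compound 1 to compound 3, where the 2-hydroxynaphthalen-1-yl in place of 4-methylphenyl on a carbon with a double bond to nitrogen brings an at least 10-fold lower number from compound 1 to compound 3 (1.00 log units; beyond the scatter); this reflects that compound 1 sits at the limit of > 64000 nM in this assay, at which 2 of the 3 values shown sit.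

Compound 4 `C#CCSc1nc(N/N=C/c2c(O)ccc3ccccc23)c2nnn(Cc3ccccc3)c2n1` keeps the 2-hydroxynaphthalen-1-yl of compound 3 and differs from it on a saturated chain carbon bound to a sulfur: ethynyl in place of ethyl on a saturated chain carbon bound to a sulfur. Going by the values given here, no measured pair isolates this change. Compound 2 carries the propargylsulfanyl and compound 1 the propylsulfanyl, but both sit at the limit and differ at the aryl as well, so their two values reveal nothing about the chain on its own. The change is therefore expected to move the number little: compound 4 is expected at 6400 nM, with a range of 2000 nM to 20000 nM. That estimate amounts to a step of no change at the digits printed from compound 3 to compound 4 (within the scatter), expected to stay within the scatter.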

Compound 4, half-maximal inhibitory concentration: 8970 nM
Beside the measured number, compound 4's estimate is 1.4-fold (0.15 log units) below it, within the range that was stated.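

With the 2-hydroxynaphthalen-1-yl held fixed, ethynyl in place of ethyl gives a 1.4-fold higher number from compound 3 to compound 4 (0.15 log units; within the scatter) in this assay, so the propylsulfanyl and propargylsulfanyl can now be compared directly, and at this position the swap does not move the number beyond the scatter. With the propargylsulfanyl held fixed, the 2-hydroxynaphthalen-1-yl in place of 4-(dimethylamino)phenyl gives an at least 7.1-fold lower number from compound 2 to compound 4 (0.85 log units; beyond the scatter), so this aryl group goes with a lower number on the propargyl chain, as it does on the propyl chain in the step of an at least 10-fold lower number from compound 1 to compound 3 (1.00 log units; beyond the scatter). Both of these aryl steps give only a minimum size and not an exact one, as each starts from a compound that returns no actual number: the limit of > 64000 nM in this assay, at which 2 of the 4 values shown sit.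

The compounds shown leave open whether a longer chain on the sulfur, such as butyl, or a chain ending in an amine or a carboxylic acid, would also leave the number in the same range. They also leave open which part of the 2-hydroxynaphthalen-1-yl goes with the lower number, something a plain naphthalen-1-yl or a 2-hydroxyphenyl in its place could help to separate.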